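Urea in place of amide on the urotensin receptor series

The source may report more compounds than this note shows. Statements on the series, on what has been measured and on what is new or still open speak of the compounds shown alone.

In an assay on HEK293 cells for binding affinity to Urotensin-2 receptor (Homo sapiens), read by radioligand binding (on this read-out higher numbers stand for weaker inhibition and lower numbers for stronger inhibition), compound 1 `CC(C)C[C@H](NC(=O)c1ccncc1)C(=O)N[C@H]1CCN(Cc2ccc(OCCCN(C)C)cc2)C1` gives 2000 nM, while compound 2 `CC(C)C[C@H](NC(=O)c1ccccc1)C(=O)N[C@H]1CCN(Cc2ccc(OCCCN(C)C)cc2)C1` gives 501 nM; the step of a 4.0-fold lower number from compound 1 to compound 2 (0.60 log units; beyond the scatter) came from phenyl in place of pyridin-4-yl on a carbonyl carbon. Going by the values given here, compound 2 thus holds the lowest number of the two, the only neighbour being compound 1. Compound 3 `CC(C)C[C@H](NC(=O)Nc1ccccc1)C(=O)N[C@H]1CCN(Cc2ccc(OCCCN(C)C)cc2)C1` carries anilino in place of phenyl on a carbonyl carbon. Among the compounds with values here, the measured step concerned the aromatic group, not the link to the carbonyl carbon, so no step bears directly on this change. For compound 3 the estimate in this assay is 700 nM (250 nM to 2000 nM), a change a 1.4-fold higher number from compound 2 to compound 3 (0.15 log units; within the scatter) expected to stay within the scatter.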

Compound 3, inhibition constant: 1000 nM
The estimate for compound 3 lay 1.4-fold (0.15 log units) below the measured number; the range from low to high includes it.
By their numbers in this assay, from the lowest: compounds 2, 3 and 1 (each within the scatter of the next, the first and the last beyond it).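

In this assay the anilino group on this carbonyl carbon gives a 2.0-fold higher number from compound 2 to compound 3 (0.30 log units; within the scatter), so turning the amide link into a urea, with its added nitrogen and hydrogen-bond donor, makes no difference that can be told apart from phenyl. The reading a 2.0-fold lower number from compound 1 to compound 3 (0.30 log units; within the scatter) likewise leaves anilino and pyridin-4-yl unseparated, although phenyl and pyridin-4-yl were separated. No measurement shown gives a reason for this result. The compounds shown leave open how phenoxy or benzylamino would read on the same carbonyl carbon, and whether pyridin-4-ylamino would match anilino.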